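A few compounds are considered here, and "the series" means these few. Any claim that something is new, unique, unknown or untested is made for them only; others in the source may bear on it.

Compound 1 `CC(C)(C)c1ccc(S(=O)(=O)Nc2ccc(Cl)cc2-c2c(O)ccc[n+]2[O-])cc1`: 491 nM
Compound 2 `CC(C)(C)c1ccc(S(=O)(=O)Nc2ccc(Cl)cc2-c2nccc(C(N)=O)c2O)cc1`: 52 nM
Compound 3 `CC(C)(C)c1ccc(S(=O)(=O)Nc2ccc(Cl)cc2-c2nc(N)ncc2O)cc1`: 4 nM

In a functional assay on isolated protein for antagonist activity at C-C chemokine receptor type 9 (Homo sapiens), read by calcium flux, with a stated time of 10 min (a lower number here means a stronger inhibitor, a higher number a weaker inhibitor), compound 1 gives 491 nM, the highest of the three numbers shown. Its nearest neighbour is compound 2, reached by a 9.4-fold lower number from compound 1 to compound 2 (0.98 log units; beyond the scatter), a modest step; its furthest is compound 3, reached by a 120-fold lower number from compound 1 to compound 3 (2.09 log units; beyond the scatter), a large one. Compound 4 `CCNc1nccnc1-c1cc(Cl)ccc1NS(=O)(=O)c1ccc(C(C)(C)C)cc1` has not yet been measured. It differs from compound 1 by a group of 9 heavy atoms (6 carbon, 3 nitrogen; one six-membered aromatic ring with 2 hetero atoms) in place of a group of 8 heavy atoms (5 carbon, 1 nitrogen, 2 oxygen; one six-membered aromatic ring with 1 hetero atom), on an aromatic carbon. Both measured steps from compound 1 exchange this same ring at the same place, and both lower the number; the ring entering compound 4 is, like that of compound 3, a six-membered aromatic ring with 2 hetero atoms. A downward step beyond the scatter is therefore expected: an 8.2-fold lower number from compound 1 to compound 4 (0.91 log units; beyond the scatter). Compound 4 is estimated at 60 nM, within 15 nM to 250 nM.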

Compound 4, half-maximal inhibitory concentration: 421 nM
Compound 4: the middle estimate sits 7.0-fold (0.85 log units) below what was measured; the whole stated range lies below it.
By their numbers in this assay, from the lowest: compound 3; then compound 2; then compounds 4 and 1 (each within the scatter of the next).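

In this assay a six-membered aromatic ring with 2 hetero atoms at this place does not by itself bring the number down, since a 1.2-fold lower number from compound 1 to compound 4 (0.07 log units; within the scatter) and the ring count alone therefore separates nothing. Rings of the same count can still lie far apart, as a 110-fold higher number from compound 3 to compound 4 (2.02 log units; beyond the scatter) shows. The ring of compound 4 also falls short of the pyridine-type ring with one hetero atom, with an 8.1-fold higher number from compound 2 to compound 4 (0.91 log units; beyond the scatter) marking that gap.

As far as these compounds go, whether a methoxy group in place of the ethylamino group on the ring of compound 4 would move the number remains open. No measurement shown explains the difference between these rings.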